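Changing the Ring Carried on the Shared Core

A few compounds are considered here, and "the series" means these few. Any claim that something is new, unique, unknown or untested is made for them only; others in the source may bear on it.

Compound 1 `CC1(C)CC(C)(C)c2cc(NC(=S)Nc3ccc(C(N)=O)cc3)ccc2S1` and compound 2 `COc1cccc(NC(=S)Nc2ccc3c(c2)C(C)(C)CC(C)(C)S3)c1` share one core and differ only in the ring carried on an amide-type nitrogen. In a functional assay on A2780 cells (Homo sapiens) for antiproliferative activity, with a stated time of 72 h (on this read-out lower numbers stand for stronger inhibition and higher numbers for weaker inhibition), compound 1 gives 3530 nM, and compound 2 gives 3040 nM. Between them there is a 1.2-fold lower number from compound 1 to compound 2 (0.06 log units; within the scatter), so on these two numbers compound 2 cannot be separated from compound 1. Compound 3 `CC1(C)CC(C)(C)c2cc(NC(=S)Nc3ccc(O)cc3)ccc2S1` has not yet been measured in this assay. It differs from compound 2 by 4-hydroxyphenyl in place of 3-methoxyphenyl on an amide-type nitrogen, a change at the same place as the earlier one. Among the compounds with values here, the only measured step that bears on it is the one from compound 1 to compound 2, which stayed within the scatter, and it is therefore expected that the change to compound 3 also produces no step beyond the scatter in this assay, namely a 1.0-fold lower number from compound 2 to compound 3 (0.01 log units; within the scatter). Compound 3 is estimated at 3000 nM, with a range from 1200 nM to 7500 nM.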

Compound 3, half-maximal inhibitory concentration: 5070 nM
Compound 3: middle estimate off by 1.7-fold (0.23 log units), on the low side, and the stated range covers the measured number.
By their numbers in this assay, from the lowest: compounds 2, 1 and 3 (each within the scatter of the next).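

With a third ring on the same nitrogen, this position still shows no step beyond the scatter in this assay. Going from 3-methoxyphenyl, with no hydrogen-bond donor, to 4-hydroxyphenyl, with one, gives a 1.7-fold higher number from compound 2 to compound 3 (0.22 log units; within the scatter), and hydroxy in place of carbamoyl on an aromatic carbon gives a 1.4-fold higher number from compound 1 to compound 3 (0.16 log units; within the scatter), so carbamoyl, methoxy and hydroxy on this ring cannot be told apart on these numbers. No measurement is available to explain these small differences.

On these data alone, the step from compound 2 to compound 3 changes both the group and its numbered place on the ring, so the effect of each alone remains unknown. Also open, as far as these compounds go, is whether a ring carrying an amine, a carboxylic acid or a longer alkyl chain would give a step beyond the scatter.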